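The source may hold more compounds than are shown below. What is called first, only, known or untested is meant among the compounds shown, and "the series" means these compounds.

Compounds measured so far:

Compound 1, `COc1ccc(/C=N/c2cc3ccccc3nc2-c2ccccc2F)c(O)c1`, 26900 nM in a functional assay on T-24 cells (Homo sapiens) for cytotoxicity, read by MTT assay, with a stated time of 48 h; on this read-out lower numbers stand for stronger inhibition and higher numbers for weaker inhibition.
Compound 2, `Oc1ccccc1/C=N/c1cc2ccccc2nc1-c1ccccc1F`, 31100 nM in this assay.

Going by the values given here, compound 2 is one of only two compounds measured in this assay, and its number and that of compound 1 lie within the scatter of each other, so neither can be ranked against the other. Among the compounds with values here, the single step recorded between them, a 1.2-fold higher number from compound 1 to compound 2 (0.06 log units; within the scatter), does not reach beyond the scatter.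

Compound 3, `Oc1cccc(/C=N/c2cc3ccccc3nc2-c2ccccc2F)c1O`, has not been measured. It differs from compound 2 by hydroxy in place of hydrogen on an aromatic carbon. Within the data shown here, no measured step bears directly on this change: the only step available concerns a methoxy group on the same ring, and it was without effect beyond the scatter. With nothing to suggest a shift in either direction, the expectation for compound 3 is a number close to that of compound 2, with an expected step of a 1.0-fold lower number from compound 2 to compound 3 (0.02 log units; within the scatter). On this basis compound 3 is estimated at 30000 nM in this assay, with a range from 12000 nM to 75000 nM.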

Compound 3, half-maximal inhibitory concentration: > 40000 nM
Compound 3: a limit, no number; the forecaster's own chance of this, stated with the estimate: 10%; middle value at least 1.3-fold (0.12 log units) from the limit.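

The reading for compound 3 in this assay is a limit of the assay and not a number: the limit of > 40000 nM in this assay, at which 1 of the 3 values shown sits.

Going by these compounds alone, the earlier compounds showed only a change involving a methoxy group, whereas this result is the first to address the ring position ortho to a hydroxy group and meta to a large group, where hydroxy in place of hydrogen gives an at least 1.2-fold higher number from compound 2 to compound 3 (0.10 log units; that floor lies within the scatter), and the change from 2-hydroxy-4-methoxyphenyl to 2,3-dihydroxyphenyl gives an at least 1.4-fold higher number from compound 1 to compound 3 (0.17 log units; that floor lies within the scatter). Both floors lie within the scatter, so the result gives no sign that the second hydroxy lowers the number, yet it cannot establish that this hydroxy raises it.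

Going by these compounds, how far compound 3 truly lies from compound 2 remains open, since only a floor is available for that step. Also open, on these data alone, is whether an amine or a carboxylic acid on this same aromatic carbon would move the number beyond the scatter of compound 2 in either direction.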